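The source may hold more compounds than are shown below. What is called first, only, known or untested is meant among the compounds shown, and "the series" means these compounds.

Compound 1 `CN(C)CCCNc1nc(-c2ccc(NC(=O)Nc3ccc(Cl)cc3Cl)cc2)nc2c(Cl)c(Cl)sc12` gives 3490 nM in a functional assay on MDA-MB-231 cells (Homo sapiens) for cytotoxicity, read by MTT assay, with a stated time of 72 h; on this read-out lower numbers stand for stronger inhibition and higher numbers for weaker inhibition. Compound 2 `Cc1ccc(NC(=O)Nc2ccc(-c3nc(NCCCN(C)C)c4sc(Cl)c(Cl)c4n3)cc2)cc1` gives 4980 nM. Compound 3 `CN(C)CCNc1nc(-c2ccc(NC(=O)Nc3ccc(Cl)cc3Cl)cc2)nc2ccsc12` gives 2450 nM.

From compound 1 to compound 2 the change is 4-methylphenyl in place of 2,4-dichlorophenyl on an amide-type nitrogen, and the step it made was a 1.4-fold higher number from compound 1 to compound 2 (0.15 log units; within the scatter). Compound 3 carries a different core from compound 1; the difference between the two cores is not broken down here, and their two values lie within the scatter of each other. Compound 4 `Cc1ccc(NC(=O)Nc2ccc(-c3nc(NCCN(C)C)c4sccc4n3)cc2)cc1` differs from compound 3 by the same change, (4-methylphenyl in place of 2,4-dichlorophenyl on an amide-type nitrogen), at the same place on the amide-type nitrogen. Since the step from compound 1 to compound 2 was a 1.4-fold higher number from compound 1 to compound 2 (0.15 log units; within the scatter), a step of similar size is expected. For compound 4 the expected step is a 1.4-fold higher number from compound 3 to compound 4 (0.14 log units; within the scatter). Compound 4 is therefore estimated at 3400 nM, with a range from 1700 nM to 7000 nM.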

Compound 4, half-maximal inhibitory concentration: 2180 nM
The estimate for compound 4 lay 1.6-fold (0.19 log units) above the measured number; low and high end bracket the measured number.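

On the second core, 4-methylphenyl in place of 2,4-dichlorophenyl on the amide-type nitrogen gave a 1.1-fold lower number from compound 3 to compound 4 (0.05 log units; within the scatter) in this assay. Set beside the earlier step, the two agree: the same change on two cores in this assay, a 1.4-fold higher number (0.15 log units; within the scatter) from compound 1 to compound 2 and a 1.1-fold lower number (0.05 log units; within the scatter) from compound 3 to compound 4, 1.6-fold (0.21 log units) apart, within the scatter of two such steps. On these two cores, then, the change stays within the scatter each time, but this does not establish a shared direction, and two cores say nothing about whether the step would stay this small on a third.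

The compounds shown leave open whether another group on that nitrogen, such as 4-methoxyphenyl or a pyridine ring, would move the number beyond the scatter. They also leave open what a longer chain or a morpholine at the end of the amine chain would do.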